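The compounds below may be only part of what the source reports. "The series", "measured", "known", "first", "only" and "open" are said of these compounds alone.

Of the compounds shown here, two sharing one core have so far been measured in an ADME assay on the whole organism (Mus musculus, strain CD-1) for pharmacokinetics, at a dose of 10 mg/kg by the oral route; a higher number here means more compound in the circulation at the dose given, a lower number less compound in the circulation. Compound 1 `COc1cc([C@](O)(CCN(C)C)[C@@H](c2cc3cc(Br)ccc3nc2OC)c2cccc(OC)c2F)cc(OC(C)C)n1` gives 9000 ng.h/mL in this assay, and compound 2 `CCCOc1cc([C@](O)(CCN(C)C)[C@@H](c2cc3cc(Br)ccc3nc2OC)c2ccnc(OC)c2OC)cc(OC)n1` gives 10900 ng.h/mL. Within the data shown here, these two values lie within the usual scatter of repeated measurements of each other, so compound 2 cannot be separated from compound 1 on these numbers; it stands level with the only other measured compound.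

Compound 3 `COc1cc([C@](O)(CCN(C)C)[C@@H](c2cc3cc(Br)ccc3nc2OC)c2ccnc(OC)c2OC)cc(OC(F)F)n1` has not yet been measured. It is related to compound 2 by a single change (difluoromethyl in place of propyl on an oxygen on an aromatic ring); cut one bond further out, the same change reads propoxy to difluoromethoxy. Among the measured compounds shown here, no measured pair in this set carries this change, so the data give neither its size nor its direction. For compound 3 the expected step is a 1.2-fold lower number from compound 2 to compound 3 (0.08 log units; within the scatter), meaning nothing beyond the scatter is anticipated. Compound 3 is estimated to give 9000 ng.h/mL in this assay, within a range from 4000 ng.h/mL to 20000 ng.h/mL.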

Compound 3, area under the concentration-time curve: 9800 ng.h/mL
For compound 3 the middle estimate is 1.1-fold (0.04 log units) below the measured one; the range from low to high includes it.
By their numbers in this assay, from the lowest: compounds 1, 3 and 2 (each within the scatter of the next).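

With compound 3, this assay gains its first pair of compounds that differ in one place: difluoromethyl in place of propyl on an oxygen on an aromatic ring (a 1.1-fold lower number from compound 2 to compound 3 (0.05 log units; within the scatter)). The two compounds stand level, so this single pair shows no separable difference when a propyl is exchanged for a difluoromethyl at this place on the core of compound 2. As this is one pair on one background, it sets no rule for the same change on other compounds, such as compound 1.

Going by these compounds, what a trifluoromethyl, a longer chain or an amine at this place would do remains open, as does whether the same exchange would stay level in other compounds. The data shown offer no measurement that bears on why this step has the size it has.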